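The source may report more compounds than this note shows. Statements on the series, on what has been measured and on what is new or still open speak of the compounds shown alone.

Series notes: a shared core carrying an amide linked to a six-membered non-aromatic ring with two nitrogens, varied only at the ring amine nitrogen. Compound 1 `CN1CCN(CC(=O)Nc2nc3ccccc3[nH]2)CC1` in a functional assay, read by spectrophotometry, with a stated time of 30 min, tested at 50 ug/mL (a lower number here means a weaker effect, a higher number a stronger effect of the compound at the concentration tested), gives 33.5%. Compound 2 `O=C(CN1CCN(c2ccccn2)CC1)Nc1nc2ccccc2[nH]1` gives 50% in this assay. Compound 3 `O=C(CN1CCN(c2ncccn2)CC1)Nc1nc2ccccc2[nH]1` gives 31% in this assay, the lowest of the three numbers, though its nearest neighbour compound 1 sits within the scatter; only compound 2 lies beyond it, by the step of a number 19 percentage points lower from compound 2 to compound 3 (beyond the scatter).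

Next in line is compound 4 `COc1ccc(N2CCN(CC(=O)Nc3nc4ccccc4[nH]3)CC2)cc1`, with the change (4-methoxyphenyl in place of pyrimidin-2-yl on an amine nitrogen in a ring).

The measured steps at this same position are a number 16.5 percentage points higher from compound 1 to compound 2 (beyond the scatter), a number 2.5 percentage points lower from compound 1 to compound 3 (within the scatter) and a number 19 percentage points lower from compound 2 to compound 3 (beyond the scatter): one aromatic replacement at the ring nitrogen raised the number modestly, the other left it within the scatter. Among the measured compounds shown here, no measured step involves an all-carbon aromatic ring, so the direction for compound 4 is uncertain; an aromatic group here has so far given either no change or a modest rise. The step of a number 9 percentage points higher from compound 3 to compound 4 (within the scatter) is expected for compound 4, a small rise toward the middle of the measured span. Compound 4 is estimated at 40% in this assay, with a range from 22% to 58%.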

Compound 4, a percentage reported as activity, at one concentration (the size of the read-out at that concentration, not a potency): 25.8%
Estimate against measurement, compound 4: 14.2 percentage points above; the measured number falls inside the stated range.
By their numbers in this assay, from the lowest: compounds 4, 3 and 1 (each within the scatter of the next); then compound 2.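

In this assay the all-carbon aromatic ring of 4-methoxyphenyl at the ring amine nitrogen gives a number 5.2 percentage points lower from compound 3 to compound 4 (within the scatter) and a number 7.7 percentage points lower from compound 1 to compound 4 (within the scatter), so this group does not separate from pyrimidin-2-yl or methyl. Only pyridin-2-yl stands apart, with a number 24.2 percentage points lower from compound 2 to compound 4 (beyond the scatter), which means that an aromatic ring at this position does not by itself go with the higher number: compound 3 and compound 4 both go against that reading. Nothing measured alongside these numbers accounts for the standing of compound 2.

Open, from the compounds shown here alone, is whether the higher number of compound 2 is particular to pyridin-2-yl or extends to pyridin-4-yl or an unsubstituted phenyl. Going by these compounds, the effect of a benzyl or an acetyl on this nitrogen also remains open.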